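The source may report more compounds than this note shows. Statements on the series, on what has been measured and on what is new or still open speak of the compounds shown alone.

Measured in a functional assay on MCF7 cells (Homo sapiens) for antiproliferative activity, read by MTT assay, with a stated time of 48 h; a lower number here means a stronger inhibitor, a higher number a weaker inhibitor:
Compound 1 `CCN(CC)CCNC(=O)c1ccc(C(CC)(CC)c2ccc(OCCC(O)(CC)CC)c(C)c2)n1CC`: 550 nM
Compound 2 `C#CCCOC(=O)c1ccc(C(CC)(CC)c2ccc(OCCC(O)(CC)CC)c(C)c2)n1CC`: > 50000 nM, which is a limit of the assay and not a number
Compound 3 `CCOC(=O)CN(C)C(=O)c1ccc(C(CC)(CC)c2ccc(OCCC(O)(CC)CC)c(C)c2)n1CC`: 3210 nM

Only two of these results are actual numbers. Of those, compound 3 has the higher, 3210 nM, which makes it the weaker inhibitor of the pair it forms with compound 1.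

Compound 4 `CCn1c(C(=O)NC(CO)CCO)ccc1C(CC)(CC)c1ccc(OCCC(O)(CC)CC)c(C)c1` differs from compound 3 in one place: a group of 7 heavy atoms (4 carbon, 1 nitrogen, 2 oxygen; no ring) in place of a group of 8 heavy atoms (5 carbon, 1 nitrogen, 2 oxygen; no ring), on a carbonyl carbon. The change falls on a carbonyl carbon, the same place where the three measured compounds differ from one another. The steps there are far from silent: an at least 90-fold higher number from compound 1 to compound 2 (1.95 log units; beyond the scatter), an at least 15-fold lower number from compound 2 to compound 3 (1.19 log units; beyond the scatter) and a 5.8-fold higher number from compound 1 to compound 3 (0.77 log units; beyond the scatter). None of them tests the group that enters in compound 4, so they show only that this place can matter.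

That group holds a nitrogen, as the matching groups of compound 1 and compound 3 do, while the group of compound 2 has none. The closest guide is therefore the modest step of a 5.8-fold higher number from compound 1 to compound 3 (0.77 log units; beyond the scatter), rather than the large steps involving compound 2. No direction is favoured, so the most likely outcome in this assay is no step beyond the scatter, though a modest step either way is possible.

This estimate means an expected 1.1-fold lower number from compound 3 to compound 4 (0.03 log units; within the scatter). The estimated value for compound 4 is 3000 nM, with an expected range of 700 nM to 13000 nM.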

Compound 4, half-maximal inhibitory concentration: 31400 nM
Compound 4: the middle estimate sits 10-fold (1.02 log units) below what was measured; the whole stated range lies below it.
By their numbers in this assay, from the lowest: compound 1; then compound 3; then compound 4. At a limit, above all of these: compound 2.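

A nitrogen in the group on this carbonyl carbon does not by itself keep the number low in this assay: the change gives a 9.8-fold higher number from compound 3 to compound 4 (0.99 log units; beyond the scatter), and the comparison with the most potent compound gives a 57-fold higher number from compound 1 to compound 4 (1.76 log units; beyond the scatter). The second step changes only the chain on the amide-type nitrogen, so the identity of that chain matters greatly here, with 3-hydroxy-1-(hydroxymethyl)propyl doing far worse than 2-(diethylamino)ethyl. The value of compound 2 is a limit of the assay and not a number. Read against that limit, the data give an at least 1.5-fold lower number from compound 2 to compound 4 (0.20 log units; that floor lies within the scatter), which is a floor only, so how far apart the two lie stays unknown: the limit of > 50000 nM in this assay, at which 1 of the 4 values shown sits.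

The compounds shown leave open whether the loss in compound 4 comes from its two hydroxyl groups, from the absence of the diethylamino end of compound 1, or from both. A chain ending in a dimethylamino or pyrrolidine group, or a plain butyl chain with no hydroxyl group on the same amide nitrogen, would help to separate these possibilities.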